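Toxicity of amide variants on a shared chromone-type core

The source may hold more compounds than are shown below. What is called first, only, known or untested is meant among the compounds shown, and "the series" means these compounds.

Measured compounds:
Compound 1, `COc1ccc2c(=O)c(/C=C/C(=O)NCc3cccc(F)c3)coc2c1`: 475000 nM
Compound 2, `Cc1ccccc1NC(=O)/C=C/c1coc2cc(O)ccc2c1=O`: 374000 nM
Compound 3, `COc1ccc(NC(=O)/C=C/c2coc3cc(OC)ccc3c2=O)cc1`: 718000 nM

All three were tested in an ADME assay on HepG2 2.2.15 cells (Homo sapiens) for cytotoxicity, read by MTT assay, with stated times of 48 h and 9 days; on this read-out higher numbers stand for lower toxicity in this test and lower numbers for higher toxicity in this test. Compound 1 stands second of the three numbers; compound 2 and compound 3 both lie within the usual scatter of it, so none of the three can be called more or less toxic than another on this evidence.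

The next compound, compound 4, `COc1ccc2c(=O)c(/C=C/C(=O)Nc3cccc(C)c3)coc2c1`, differs from compound 1 in one place: 3-methylphenyl in place of 3-fluorobenzyl on an amide-type nitrogen. Within the data shown here, only one measured step bears on it, the change of the same amide substituent from compound 1 to compound 3, which gave a 1.5-fold higher number from compound 1 to compound 3 (0.18 log units; within the scatter). That step barely moved the number, and compound 2, which carries a methylphenyl on the same amide nitrogen, also sits in the same range. A change of the amide substituent within this small set has so far produced nothing beyond the scatter, so no step beyond the scatter is expected for compound 4 either.

Compound 4 is therefore expected to give 520000 nM in this assay, with a likely range from 280000 nM to 1000000 nM, because the comparable step a 1.5-fold higher number from compound 1 to compound 3 (0.18 log units; within the scatter) stayed within the scatter. The expected step is a 1.1-fold higher number from compound 1 to compound 4 (0.04 log units; within the scatter).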

Compound 4, half-maximal cytotoxic concentration: 554000 nM
Estimate against measurement, compound 4: 1.1-fold (0.03 log units) below; the range from low to high includes it.
By their numbers in this assay, from the lowest: compounds 2, 1, 4 and 3 (each within the scatter of the next).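

In this assay the swap of 3-fluorobenzyl for 3-methylphenyl on the amide-type nitrogen gives a 1.2-fold higher number from compound 1 to compound 4 (0.07 log units; within the scatter) and stays within the scatter, even though it replaces a benzyl group with a phenyl group and removes the fluorine. The swap of 4-methoxyphenyl for 3-methylphenyl at the same place gives a 1.3-fold lower number from compound 3 to compound 4 (0.11 log units; within the scatter), also within the scatter, so among compounds 1, 3 and 4 this assay does not separate these three substituents. Nothing measured here explains why the number stays so flat.

Every substituent compared at this position carries a six-membered aromatic ring of carbon only. On these data alone, whether an amine, a carboxylic acid or a longer chain on the same nitrogen would shift the number beyond the scatter remains open.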